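The source may hold more compounds than are shown below. What is called first, only, known or untested is meant among the compounds shown, and "the series" means these compounds.

In a functional assay on HT-29 cells (Homo sapiens) for antiproliferative activity, read by MTT assay, with a stated time of 72 h (on this read-out higher numbers stand for weaker inhibition and lower numbers for stronger inhibition), compound 1 `COc1cc(-c2nccn2-c2ccc(C)cc2)cc(OC)c1OC` gives 1600 nM and compound 2 `COc1cc(-c2nccn2-c2cccc(C)c2)cc(OC)c1OC` gives 14600 nM, the higher of the two numbers and so the weaker inhibition. Compound 3 `COc1ccc(-n2ccnc2-c2cc(OC)c(OC)c(OC)c2)cc1` has 4-methoxyphenyl in place of 3-methylphenyl on an aromatic nitrogen. Among the compounds with values here, only one measured step bears on this change: swapping 4-methylphenyl for 3-methylphenyl gave a 9.1-fold higher number from compound 1 to compound 2 (0.96 log units; beyond the scatter). Within the data shown here, compound 3 returns to a 4-substituted phenyl, though no measured compound carries methoxyphenyl, so a similar step back down is expected, an 8.1-fold lower number from compound 2 to compound 3 (0.91 log units; beyond the scatter). For compound 3 the estimated value is 1800 nM, with an expected range from 250 nM to 9000 nM.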

Compound 3, half-maximal inhibitory concentration: 13100 nM
The estimate for compound 3 lay 7.3-fold (0.86 log units) below the measured number; the measured number lies above the stated range.
By their numbers in this assay, from the lowest: compound 1; then compounds 3 and 2 (each within the scatter of the next).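

Carrying a group on the phenyl as 4-methoxyphenyl does not by itself bring back the stronger inhibition of 4-methylphenyl: methoxy in place of methyl gives an 8.2-fold higher number from compound 1 to compound 3 (0.91 log units; beyond the scatter). Against 3-methylphenyl, 4-methoxyphenyl gives a 1.1-fold lower number from compound 2 to compound 3 (0.05 log units; within the scatter), so the earlier step cannot be read as a matter of group placement alone, and of these three compounds only compound 1 stands apart. Nothing available explains this difference. Going by these compounds, whether a chlorine, an amine or an ethyl chain on the phenyl would match 4-methylphenyl remains open. So does how 3-methoxyphenyl would compare.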